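Glycoside esters at the limit: a hydroxy addition

The source may report more compounds than this note shows. Statements on the series, on what has been measured and on what is new or still open speak of the compounds shown alone.

Two esters of one glycosylated core have been measured in a functional assay on Bel-7402 cells (Homo sapiens) for cytotoxicity, read by MTT assay, with a stated time of 4 days; a lower number here means a stronger inhibitor, a higher number a weaker inhibitor. Compound 1 `COc1cc(C(=O)O[C@@H]2C[C@](C)(O)[C@H]3[C@H](O[C@@H]4O[C@H](CO)[C@@H](O)[C@H](O)[C@H]4O)OC=C[C@H]32)cc(OC)c1O[C@@H]1O[C@@H](C)[C@H](O)[C@@H](O)[C@H]1O` gives > 10000 nM, which is a limit of the assay and not a number. Compound 2 `CC(/C=C/[C@@]1(O)C(C)(C)CCC[C@@]1(C)O)=C\C(=O)O[C@@H]1C[C@](C)(O)[C@H]2[C@H](O[C@@H]3O[C@H](CO)[C@@H](O)[C@H](O)[C@H]3O)OC=C[C@H]21` likewise gives > 10000 nM, again a limit and not a number. Both values sit at the limit of > 10000 nM in this assay, at which 2 of the 2 values shown sit, so compound 2 stands at the same limit as compound 1, and no order between the two can be read from the numbers shown; no step between measured compounds is available in the series.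

Compound 3 `CC(/C=C/[C@@]1(O)C(C)(C)C[C@H](O)C[C@@]1(C)O)=C\C(=O)O[C@@H]1C[C@](C)(O)[C@H]2[C@H](O[C@@H]3O[C@H](CO)[C@@H](O)[C@H](O)[C@H]3O)OC=C[C@H]21` is not yet measured. It differs from compound 2 by hydroxy in place of hydrogen on a saturated ring carbon. Nothing measured here bears on such a change, and with compound 2 already at the limit, no step beyond the usual scatter is expected in this assay, in either direction. Compound 3 is therefore expected to remain at the limit, with an estimate of 20000 nM and a range from 6000 nM to 80000 nM. The estimated step that the limit leaves unreadable from compound 2 to compound 3 is expected to lie within the scatter.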

Compound 3, half-maximal inhibitory concentration: > 10000 nM
Compound 3 was reported as a limit; the forecaster's own chance of this, stated with the estimate: 85%; the middle value lies beyond the limit too.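

In this assay compound 3 gives > 10000 nM, a limit of the assay and not a number. No step from compound 2 to compound 3 can be read, as both stand at the same limit: the limit of > 10000 nM in this assay, at which 3 of the 3 values shown sit.

The compounds shown leave open what hydroxy in place of hydrogen on the saturated ring carbon does to cytotoxicity, and how the three esters rank.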